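Swapping a Side Chain at the Assay Limit

The source may report more compounds than this note shows. Statements on the series, on what has been measured and on what is new or still open speak of the compounds shown alone.

In an ADME assay on BaF3 cells (Mus musculus) for cytotoxicity (on this read-out higher numbers stand for an effect only at larger amounts of compound and lower numbers for an effect already at smaller amounts), compound 1 (`Nc1nc2ccc(-c3cccc(C(=O)Nc4cccc(C(F)(F)F)c4)c3)nc2s1`) gives > 10000 nM, which is a limit and not a number. Compound 2 (`CC(=O)Nc1nc2ccc(-c3cccc(C(=O)Nc4cccc(C(F)(F)F)c4)c3)nc2s1`) also gives a limit, > 10000 nM. Going by these compounds, compound 3 (`CC(=O)N1CCN(CCC(=O)Nc2nc3ccc(-c4cccc(C(=O)Nc5cccc(C(F)(F)F)c5)c4)nc3s2)CC1`) stands at a limit too, > 10000 nM, so its true place is unknown. Compound 4 (`O=C(Nc1nc2ccc(-c3cccc(C(=O)Nc4cccc(C(F)(F)F)c4)c3)nc2s1)NC1CCNCC1`) carries (piperidin-4-yl)amino in place of 2-(4-acetylpiperazin-1-yl)ethyl on a carbonyl carbon. The earlier changes offer only a step that the two limits leave unreadable from compound 1 to compound 2 and a step that the two limits leave unreadable from compound 2 to compound 3, so neither gives a size to carry over. The expectation for compound 3 onward therefore rests on (the limit of > 10000 nM in this assay, at which 3 of the 3 values shown sit), and no clear shift is expected in this assay. The expected change is a number no higher from compound 3 to compound 4 (the limit leaves the size open). Compound 4 is estimated at 10000 nM, with an expected range of 3000 nM to 20000 nM.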

Compound 4, half-maximal effective concentration: > 10000 nM
Compound 4 ended at the assay's limit (the forecaster's own chance of this, stated with the estimate: 70%); the middle value sits exactly at the limit.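

In this assay compound 4 gives > 10000 nM, which is a limit and not a number. Its steps from compound 1, compound 2 and compound 3 cannot be read. The compounds shown leave open whether these side chains change the true values at all.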